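The compounds below may be only part of what the source reports. "The series", "measured", "known", "first", "only" and "open" are said of these compounds alone.

Of the compounds shown here, three that share one core have been measured in a physicochemical assay for lipophilicity; a higher number here means a more lipophilic compound, a lower number a more polar compound. Compound 1 `O=C1OCCN1c1cc(C(F)(F)F)ccc1[C@H]1CCOc2cc(S(=O)(=O)Nc3nccs3)ccc21` gives 2.1 and compound 2 `Cc1nc(-c2cc(C(F)(F)F)ccc2[C@H]2CCOc3cc(S(=O)(=O)Nc4nccs4)ccc32)co1` gives 2.9. Compound 3 `O=S(=O)(Nc1nccs1)c1ccc2c(c1)OCC[C@@H]2c1ccc(C(F)(F)F)cc1-c1ccc(F)cn1` gives 3.5 and stands highest of the three. Compound 4 `O=S(=O)(Nc1nccs1)c1ccc2c(c1)OCC[C@@H]2c1ccc(C(F)(F)F)cc1N1CCNCC1` keeps the core but carries piperazin-1-yl in place of 5-fluoropyridin-2-yl on an aromatic carbon, meta to a trifluoromethyl group (piperazin-1-yl in place of 5-fluoropyridin-2-yl on an aromatic carbon).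

All three measured steps change this same place. Moving from 2-oxo-1,3-oxazolidin-3-yl to 5-fluoropyridin-2-yl gave a number 1.40 log units higher from compound 1 to compound 3 (beyond the scatter) and is the largest of them. Moving to 2-methyl-1,3-oxazol-4-yl gave a number 0.80 log units higher from compound 1 to compound 2 (beyond the scatter), and moving on from there to 5-fluoropyridin-2-yl gave a number 0.60 log units higher from compound 2 to compound 3 (beyond the scatter). Of these three compounds, only compound 1 has a non-aromatic ring in this place, and it has the lowest number at 2.1. Neither of the other two goes against this, although three compounds make a thin basis. Piperazin-1-yl is also a non-aromatic ring, but no measured compound carries it, so the comparison is only indirect. A large step downward is expected, similar in size to the largest measured one. The expected change is a number 1.80 log units lower from compound 3 to compound 4 (beyond the scatter). The estimated value for compound 4 is 1.7, with an expected range from 1 to 2.5.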

Compound 4, distribution coefficient: 1.4
Estimate against measurement, compound 4: 0.30 log units above; the measured number falls inside the stated range.
By their numbers in this assay, from the lowest: compound 4; then compound 1; then compound 2; then compound 3.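

In this assay, piperazin-1-yl in place of the aromatic 5-fluoropyridin-2-yl gave a number 2.10 log units lower from compound 3 to compound 4 (beyond the scatter), the largest step seen at this position, and in place of the aromatic 2-methyl-1,3-oxazol-4-yl it gave a number 1.50 log units lower from compound 2 to compound 4 (beyond the scatter). The two compounds with a non-aromatic ring in this place, compound 1 and compound 4, now hold the two lowest numbers, and neither of the other two compounds goes against this, although four compounds are still a small set. The two non-aromatic rings do not match each other, however: piperazin-1-yl in place of 2-oxo-1,3-oxazolidin-3-yl gave a number 0.70 log units lower from compound 1 to compound 4 (beyond the scatter), so having a non-aromatic ring here does not alone fix the number.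

The data offer no measured reason for any of these differences. A morpholine ring, with an oxygen in place of the second ring nitrogen, or a piperidine ring, with carbon there, would help show whether the low number of compound 4 goes with that nitrogen or with the non-aromatic ring as a whole.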